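Dichloro Extension of a Chlorophenyl Prenyl Diene

The compounds below may be only part of what the source reports. "The series", "measured", "known", "first", "only" and "open" are said of these compounds alone.

The series rests on two cores. Compound 1 is `CC(C)=CCC[C@@](C)(/C=C/c1ccccc1)/C=C/c1ccc(O)cc1`, and compound 2 is `CC(C)=CCC[C@](C)(/C=C/c1ccc(O)cc1)/C=C/c1cccc(Cl)c1`, obtained from it by chloro in place of hydrogen on an aromatic carbon. Compound 3 is `C=C[C@@](C)(/C=C/c1ccc(-c2ccc(Cl)cc2)cc1)CCC=C(C)C`, and compound 4, not yet measured, is `C=C[C@@](C)(/C=C/c1ccc(-c2ccc(Cl)c(Cl)c2)cc1)CCC=C(C)C`, obtained from compound 3 by chloro in place of hydrogen on an aromatic carbon. The difference between the two cores, that of compound 1 and that of compound 3, is not broken down here.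

In an ADME assay on BJ cells (Homo sapiens) for cytotoxicity, with a stated time of 72 h (on this read-out lower numbers stand for an effect already at smaller amounts and higher numbers for an effect only at larger amounts of compound), compound 1 reports only a limit of > 36600 nM. Compound 2 likewise reports only a limit of > 36600 nM. The step from the first to the second is therefore a step that the two limits leave unreadable from compound 1 to compound 2. Compound 3 also reports only a limit of > 36600 nM. All three measured compounds thus sit on (the limit of > 36600 nM in this assay, at which 3 of the 3 values shown sit).

The change from compound 3 to compound 4 is the same kind of change as that from compound 1 to compound 2: a chloro in place of hydrogen on an aromatic carbon, meta to a large group in both, but in compound 4 the new chloro is also ortho to a chloro group, which the place in compound 2 is not. Within the data shown here, with no measured step readable, the expectation for compound 4 is that it remains at the limit like its neighbours, giving an expected step that the limit leaves unreadable from compound 3 to compound 4. Compound 4 is therefore expected to give about 50000 nM in this assay, most likely again only as a limit.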

Compound 4, half-maximal effective concentration: > 36600 nM
Compound 4: no number, only a limit; the forecaster's own chance of this, stated with the estimate: 85%; the middle value is on the limit's open side.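

Compound 4 also reports only a limit, > 36600 nM, in this assay. The step from compound 3 to compound 4 therefore cannot be read, and no size can be given for the change from 4-chlorophenyl to 3,4-dichlorophenyl. All the compounds shown sit at one value: the limit of > 36600 nM in this assay, at which 4 of the 4 values shown sit.

What the compounds shown leave open is whether any chloro change in either core alters the read-out, since none gives a number.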